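A few compounds are considered here, and "the series" means these few. Any claim that something is new, unique, unknown or untested is made for them only; others in the source may bear on it.

The series rests on a shared thiosemicarbazone tail: compound 1 `Cc1cccc(Cn2cc(/C=N/NC(N)=S)c3ccccc32)c1`, compound 2 `COc1ccc(/C=N/NC(N)=S)c2ccccc12` and compound 3 `CCOc1ccc(/C=N/NC(N)=S)c2ccccc12` were tested in a toxicity assay on THP-1 cells (Homo sapiens) for cytotoxicity, read by MTT assay, with a stated time of 72 h; a higher number here means that more compound is needed for the effect, a lower number that less compound is needed. In this assay compound 1 gives 32000 nM. In this assay compound 2 gives 47000 nM. For compound 3 this assay reports only a limit, > 200000 nM, so its true number is not known beyond that bound. For the measured compounds named here, compound 3 therefore stands at the edge of the measured range, together with the one reading that sits at the limit of > 200000 nM in this assay, at which 1 of the 3 values shown sits.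

The unmeasured compound 4 `NC(=S)N/N=C/c1ccc(OCC2CCCCC2)c2ccccc12` differs from compound 3 by cyclohexyl in place of methyl on a saturated chain carbon bound to an oxygen on an aromatic ring. Going by the values given here, the one measured step that touches the same position is an at least 4.2-fold higher number from compound 2 to compound 3 (0.62 log units; beyond the scatter), which went toward a higher number. Among the compounds with values here, that step points in one direction only, from hydrogen to methyl, and no measured pair shows what a larger saturated group does there; compounds 1 and 2 differ in other places and do not speak to it.

With compound 3 already at a limit, a further change at the same position is expected to leave compound 4 at or beyond that limit, so the expected step is a step that the limit leaves unreadable from compound 3 to compound 4. In this assay compound 4 is estimated at 300000 nM, within 100000 nM to 1000000 nM, most likely reported as a limit.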

Compound 4, half-maximal effective concentration: 150000 nM
The estimate for compound 4 lay 2.0-fold (0.30 log units) above the measured number; the measured number falls inside the stated range.
By their numbers in this assay, from the lowest: compounds 1 and 2 (each within the scatter of the next); then compound 4. At a limit, above all of these: compound 3.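

For the compounds shown here, compound 4 shows that a much larger saturated group on the saturated chain carbon bound to an oxygen on an aromatic ring does not carry the number further up in this assay: the reading is an at least 1.3-fold lower number from compound 3 to compound 4 (0.12 log units; that floor lies within the scatter), whereas the earlier compounds offered only the step from hydrogen to methyl at this place. Measured against the compound with no added group, the change still counts upward, with a 3.2-fold higher number from compound 2 to compound 4 (0.50 log units; beyond the scatter), so cyclohexyl, like methyl, ends on the higher side of hydrogen here. How far compound 4 lies under compound 3 cannot be sized, because compound 3 is held only at a limit: the limit of > 200000 nM in this assay, at which 1 of the 4 values shown sits.

The compounds shown leave open whether the number in this assay follows any steady course between methyl and cyclohexyl, since a propyl or butyl chain, a flat phenyl ring or a ring carrying an amine or a carboxylic acid does not appear at this place. They also leave open whether the same change would act alike on the core of compound 1, which differs from the others in more than one place.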